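Aniline to benzylamine swap on the shared core

The source may hold more compounds than are shown below. What is called first, only, known or untested is meant among the compounds shown, and "the series" means these compounds.

Compound 2 `Cc1ccc(Cl)cc1Nc1nc(C(F)(F)F)ccc1CNC(=O)C(C)c1ccc(NS(C)(=O)=O)c(F)c1` gives the lowest number of the two measured, 14 nM in a functional assay on CHO-K1 cells for antagonist activity at transient receptor potential cation channel subfamily V member 1 (Homo sapiens), read by FLIPR (on this read-out higher numbers stand for weaker inhibition and lower numbers for stronger inhibition), against compound 1 `CC(C(=O)NCc1ccc(C(F)(F)F)nc1Nc1ccccc1)c1ccc(NS(C)(=O)=O)c(F)c1` at 59.6 nM. Compound 3 `CC(C(=O)NCc1ccc(C(F)(F)F)nc1NCc1ccc(Cl)cc1)c1ccc(NS(C)(=O)=O)c(F)c1` carries 4-chlorobenzyl in place of 5-chloro-2-methylphenyl on a nitrogen on an aromatic ring. For the measured compounds named here, the only measured step, a 4.3-fold lower number from compound 1 to compound 2 (0.63 log units; beyond the scatter), concerns a different change at the same nitrogen and gives no direct guide to inserting a methylene there. Compound 3 is therefore expected to sit near compound 2, with an estimated step of a 2.9-fold higher number from compound 2 to compound 3 (0.46 log units; beyond the scatter) toward a somewhat higher number. Compound 3 is expected to give about 40 nM, within 10 nM to 200 nM.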

Compound 3, inhibition constant: 65.7 nM
Estimate against measurement, compound 3: 1.6-fold (0.22 log units) below, and the stated range covers the measured number.
By their numbers in this assay, from the lowest: compound 2; then compounds 1 and 3 (each within the scatter of the next).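

At the nitrogen on the aromatic ring, 4-chlorobenzyl in place of 5-chloro-2-methylphenyl gives a 4.7-fold higher number from compound 2 to compound 3 (0.67 log units; beyond the scatter) in this assay, so the same atoms joined differently do not keep the low number of compound 2. Against the plain phenyl group, 4-chlorobenzyl gives a 1.1-fold higher number from compound 1 to compound 3 (0.04 log units; within the scatter), which leaves compound 1 and compound 3 level. No measured evidence accounts for these results.

As far as these compounds go, it remains open how a plain benzyl group or a longer phenethyl chain would read at this nitrogen. The compounds also leave unresolved whether the methyl or the chlorine of 5-chloro-2-methylphenyl accounts for the lower number of compound 2.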